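Methoxy for Trifluoromethyl in a Cell Growth Assay

The compounds below may be only part of what the source reports. "The series", "measured", "known", "first", "only" and "open" are said of these compounds alone.

Three compounds were measured in a functional assay on HCC827 cells (Homo sapiens) for inhibition, read by MTT assay, with a stated time of 48 h, tested at 10 uM; a lower number here means less inhibition, a higher number more inhibition at the concentration tested (going by the name of the read-out):
compound 1, `COc1ccc(C(F)(F)F)cc1Nc1cc(NC(=O)Nc2c(Cl)cccc2Cl)ncn1`, gives 68.7%;
compound 2, `COc1cc(Nc2cc(NC(=O)Nc3c(Cl)cccc3Cl)ncn2)cc(OC)c1`, gives 73.7%;
compound 3, `COc1cc(Nc2cc(NC(=O)Nc3c(Cl)cccc3Cl)ncn2)cc(C(F)(F)F)c1`, gives 57.7%.

Compound 3 and compound 2 differ in one place: methoxy in place of trifluoromethyl on an aromatic carbon That change brought a number 16 percentage points higher from compound 3 to compound 2 (beyond the scatter). Compound 1 and compound 3 contain the same atoms joined differently; the difference between the two cores is not broken down here. The numbers of compound 1 and compound 2 lie within the scatter of each other, while compound 1 stands above compound 3 by more than the scatter.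

Compound 4, `COc1ccc(OC)c(Nc2cc(NC(=O)Nc3c(Cl)cccc3Cl)ncn2)c1`, has not yet been measured. Among the measured compounds shown here, it is related to compound 1 by methoxy in place of trifluoromethyl on an aromatic carbon This is the same kind of change as the one from compound 3 to compound 2, but not the same: there the new methoxy is meta to a methoxy group, here it is para to a methoxy group. Because the earlier step was a number 16 percentage points higher from compound 3 to compound 2 (beyond the scatter), a rise of similar kind is expected, tempered for the different surroundings, so in this assay the expected step is a number 10.3 percentage points higher from compound 1 to compound 4 (beyond the scatter). Compound 4 is therefore estimated at 79%, expected to fall between 64% and 91%.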

Compound 4, a percentage reported as inhibition, at one concentration (the size of the read-out at that concentration, not a potency): 94.1%
Compound 4: the middle estimate sits 15.1 percentage points below what was measured, outside the stated range (above it).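

In this assay, methoxy in place of trifluoromethyl brought a number 25.4 percentage points higher from compound 1 to compound 4 (beyond the scatter). Set beside the earlier case, the change raises the number on both cores, and the two rises cannot be told apart in size: the same change on two cores in this assay, a number 16 percentage points higher (beyond the scatter) from compound 3 to compound 2 and a number 25.4 percentage points higher (beyond the scatter) from compound 1 to compound 4, 9.4 percentage points apart, within the scatter of two such steps So on these two cores the gain carried over, but two pairs cannot show that it would hold on a third core, and they do not explain why the change raises the number; each reading also comes from one concentration, so neither step is a change in potency.

The compounds shown leave open whether other groups in the same place, such as an amine, a nitrile or a carboxylic acid, would match methoxy or fall short of it. They also leave open how a longer chain such as ethoxy would behave, and whether the gain would survive on a core without the two chlorine atoms.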